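Exchanging pyridin-2-yl for phenyl in compound 3

A few compounds are considered here, and "the series" means these few. Any claim that something is new, unique, unknown or untested is made for them only; others in the source may bear on it.

In an ADME assay on microsomes from liver (Mus musculus, strain CD-1) for metabolic stability, read by LC-MS, with a stated time of 60 min, tested at 20 uM (on this read-out higher numbers stand for a longer-lived compound and lower numbers for a shorter-lived compound), compound 3 `CC(Sc1nc2nn(C3COC3)cc2c(=O)n1-c1ccccc1)c1ccccn1` gives > 1 h, which is a limit of the assay and not a number. The two other measured compounds have numbers: compound 2 `O=c1c2cn(C3COC3)nc2nc(SCc2cccc(F)c2)n1-c1ccccc1` gives 0.383 h, and compound 1 `C[C@@H](Sc1nc2c(cnn2C)c(=O)n1-c1ccccc1)c1ccccc1` gives 0.133 h.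

Compound 4 `CC(Sc1nc2nn(C3COC3)cc2c(=O)n1-c1ccccc1)c1ccccc1` differs from compound 3 in one place: phenyl in place of pyridin-2-yl on a saturated chain carbon bound to a saturated chain carbon and a sulfur.

Within the data shown here, one measured step bears on this change. Placing 1-(pyridin-2-yl)ethyl in place of 3-fluorobenzyl on a sulfur gave an at least 2.6-fold higher number from compound 2 to compound 3 (0.41 log units; beyond the scatter), a step beyond the scatter. That step also removes 3-fluorobenzyl, so it does not isolate the pyridin-2-yl group. Compound 1 carries 1-phenylethyl too, but on a different core, so it offers only loose guidance.

Removing the pyridin-2-yl group is expected to give back much of the measured gain, leaving compound 4 near compound 2 rather than compound 3. The expected move in this assay is an at least 2.2-fold lower number from compound 3 to compound 4 (0.34 log units; beyond the scatter), toward a shorter half-life and beyond the scatter. Compound 4 is estimated at 0.45 h, with an expected range from 0.2 h to 1 h.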

Compound 4, half-life: 0.783 h
Compound 4: middle estimate off by 1.7-fold (0.24 log units), on the low side; the range from low to high includes it.
By their numbers in this assay, from the lowest: compound 1; then compound 2; then compound 4. At a limit, above all of these: compound 3.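

In this assay, the exchange of phenyl for pyridin-2-yl on a saturated chain carbon bound to a saturated chain carbon and a sulfur is now seen on its own, and it reads as an at least 1.2-fold lower number from compound 3 to compound 4 (0.10 log units; that floor lies within the scatter), so this floor does not establish that the nitrogen of pyridin-2-yl matters on this read-out. The second step, a 2.0-fold higher number from compound 2 to compound 4 (0.31 log units; beyond the scatter), shows that 1-phenylethyl in place of 3-fluorobenzyl on a sulfur already gives a rise beyond the scatter, with no pyridin-2-yl present, so at least part of the rise seen with 1-(pyridin-2-yl)ethyl does not depend on that nitrogen. How much pyridin-2-yl adds on top of this stays unresolved, since compound 3 is recorded only as a limit and not as a number: the limit of > 1 h in this assay, at which 1 of the 4 values shown sits.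

The compounds shown leave open whether the rise from 3-fluorobenzyl to 1-phenylethyl follows from the extra methyl or from the loss of fluorine, a question that plain benzyl or 1-(3-fluorophenyl)ethyl on the sulfur would separate. They also leave open how pyridin-3-yl or pyridin-4-yl would compare with pyridin-2-yl here.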